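Cyclopentyl in place of benzyltriazolyl on the chain carbon

A few compounds are considered here, and "the series" means these few. Any claim that something is new, unique, unknown or untested is made for them only; others in the source may bear on it.

Compound 3 `CCN1CCN(c2ccc(-c3nn(Cc4cn(Cc5ccccc5)nn4)c4nc(NC)ncc34)cn2)CC1` gives 6200 nM in an assay for inhibition of proto-oncogene tyrosine-protein kinase receptor Ret (Homo sapiens), read by 33P incorporation, in the presence of a further agent that is not named here (a lower number here means a stronger inhibitor, a higher number a weaker inhibitor), the highest number among the three measured compounds. Compound 2 `CNc1ncc2c(-c3ccc(N4CCN(C)CC4)nc3)nn(Cc3cn(Cc4ccccc4)nn3)c2n1` gives 900 nM, and compound 1 `CNc1ncc2c(-c3ccc(N4CCNCC4)nc3)nn(CC3CCCC3)c2n1` gives 50 nM. For the measured compounds named here, the only single-point step recorded is a 6.9-fold higher number from compound 2 to compound 3 (0.84 log units; beyond the scatter). Compound 4 `CCN1CCN(c2ccc(-c3nn(CC4CCCC4)c4nc(NC)ncc34)cn2)CC1` differs from compound 3 by cyclopentyl in place of 1-benzyl-1H-1,2,3-triazol-4-yl on a saturated chain carbon bound to an aromatic nitrogen. Going by the values given here, no measured pair isolates this change; compound 1 and compound 2 differ in two places at once, so their values only hint that a cyclopentyl-bearing compound sat at a lower number. On that basis a lower number is expected, with the step estimated as a 16-fold lower number from compound 3 to compound 4 (1.19 log units; beyond the scatter). Compound 4 is therefore estimated at 400 nM, within a range from 80 nM to 2000 nM.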

Compound 4, half-maximal inhibitory concentration: 440 nM
Beside the measured number, compound 4's estimate is 1.1-fold (0.04 log units) below it, and the stated range covers the measured number.
By their numbers in this assay, from the lowest: compound 1; then compound 4; then compound 2; then compound 3.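

Cyclopentyl in place of 1-benzyl-1H-1,2,3-triazol-4-yl on a saturated chain carbon bound to an aromatic nitrogen now stands as a single change, and it lowers the number by a large step (a 14-fold lower number from compound 3 to compound 4 (1.15 log units; beyond the scatter)). Ethyl in place of hydrogen on the amine nitrogen in a ring raises the number with cyclopentyl present (an 8.8-fold higher number from compound 1 to compound 4 (0.94 log units; beyond the scatter)), as ethyl in place of methyl does with the benzyltriazolyl group (a 6.9-fold higher number from compound 2 to compound 3 (0.84 log units; beyond the scatter)). Nothing available explains either step.

On these data alone, whether cyclopropyl or cyclohexyl would suit this chain carbon better remains open. So does the effect of a hydroxyethyl group on the ring amine nitrogen.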